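The compounds below may be only part of what the source reports. "The series", "measured", "known", "first", "only" and "open" are said of these compounds alone.

compound 1 `CNC(=O)[C@@H](CO)NCc1ccc(OCc2cccc(F)c2)cc1` - 6.4 mg/kg
compound 2 `C[C@H](NCc1ccc(OCCCCc2ccccc2)cc1)C(N)=O` - 12.4 mg/kg

Within the data shown here, in a functional assay on the whole organism with Rattus norvegicus as the target, with a stated time of 60 min (on this read-out higher numbers stand for an effect only at larger amounts of compound and lower numbers for an effect already at smaller amounts), compound 2 at 12.4 mg/kg stands within the scatter of compound 1 at 6.4 mg/kg and no single-place step links them. Compound 3 `C[C@H](NCc1ccc(OCCCCCc2ccccc2)cc1)C(N)=O` differs from compound 2 by benzyl in place of phenyl on a saturated chain carbon, four bonds along the chain from an oxygen on an aromatic ring with benzyl in place of phenyl on a saturated chain carbon, four bonds along the chain from an oxygen on an aromatic ring. Among the measured compounds shown here, no measured pair shows this change, so no step beyond the scatter is expected in this assay in either direction. The estimated step of a 1.1-fold higher number from compound 2 to compound 3 (0.05 log units; within the scatter) is small. For compound 3 the expected value is 14 mg/kg with an estimated range of 6 mg/kg to 35 mg/kg as its span.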

Compound 3, dose for half-maximal effect: 12.5 mg/kg
The estimate for compound 3 lay 1.1-fold (0.05 log units) above the measured number, and the stated range covers the measured number.
By their numbers in this assay, from the lowest: compounds 1, 2 and 3 (each within the scatter of the next).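

Benzyl in place of phenyl on a saturated chain carbon, four bonds along the chain from an oxygen on an aromatic ring, gives a 1.0-fold higher number from compound 2 to compound 3 (0.00 log units; within the scatter) in this assay. Among these compounds, this is the first single-place reading, and it shows that this change at this place leaves the read-out within the scatter. Nothing measured bears on the reason for this result.

Still open, from the compounds shown here alone, is whether a longer chain at this place also stays within the scatter in this assay. Going by these compounds, whether an amine or a carboxylic acid in place of the terminal phenyl moves the number is also open.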